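A few compounds are considered here, and "the series" means these few. Any claim that something is new, unique, unknown or untested is made for them only; others in the source may bear on it.

Of the compounds shown here, three have so far been measured in an ADME assay on BTI cells for inhibition of Amine oxidase [flavin-containing] A (Homo sapiens), read by fluorescence and Amplex Red, with a stated time of 15 min, tested at 100 uM; on this read-out lower numbers stand for less inhibition and higher numbers for more inhibition at the one concentration tested (going by the name of the read-out). Compound 1 `C#CCN(C)CCCCOc1ccc2c(c1)CCCC2=O` gives 30.9% in this assay. Compound 2 `C#CCN(C)CCCCCCOc1ccc2c(c1)CCCC2=O` differs from compound 1 by one change, (2-(methyl(propargyl)amino)ethyl in place of methyl(propargyl)amino on a saturated chain carbon, four bonds along the chain from an oxygen on an aromatic ring), and in this assay compound 2 gives 25%, so that the step is a number 5.9 percentage points lower from compound 1 to compound 2 (within the scatter). Compound 3 `C#CCN(C)CCCCOc1ccc(C(C)=O)cc1` is built on a second core; the difference between the two cores is not broken down here. In this assay compound 3 gives 28.6%, which lies within the scatter of both compound 1 and compound 2.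

Compound 4 `C#CCN(C)CCCCCCOc1ccc(C(C)=O)cc1` has not yet been measured in this assay. It differs from compound 3 by 2-(methyl(propargyl)amino)ethyl in place of methyl(propargyl)amino on a saturated chain carbon, four bonds along the chain from an oxygen on an aromatic ring, the same change that separates compound 1 from compound 2, made at the same place. Because the earlier step of a number 5.9 percentage points lower from compound 1 to compound 2 (within the scatter) stayed within the scatter, the expected step is a number 4.6 percentage points lower from compound 3 to compound 4 (within the scatter). Compound 4 is therefore estimated at 24%, with a likely range from 14% to 34%.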

Compound 4, a percentage reported as inhibition, at one concentration (the size of the read-out at that concentration, not a potency): 37.3%
Compound 4: the middle estimate sits 13.3 percentage points below what was measured, outside the stated range (above it).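

In this assay the change to 2-(methyl(propargyl)amino)ethyl from methyl(propargyl)amino gives a number 8.7 percentage points higher from compound 3 to compound 4 (within the scatter), so this step taken alone is not a clear change. Set beside the earlier step, however, the same change does not carry over from one core to the other as a fixed amount: the same change on two cores in this assay, a number 5.9 percentage points lower (within the scatter) from compound 1 to compound 2 and a number 8.7 percentage points higher (within the scatter) from compound 3 to compound 4, 14.6 percentage points apart, beyond the scatter of two such steps. For the compounds shown here, this shows that a step measured on the core of compound 1 cannot simply be transferred to the core of compound 3, but with only two pairs, each step within the scatter on its own, and a single tested concentration, it establishes neither a general rule for the series nor a reason for the gap.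

From the compounds shown here alone, it remains open whether a longer chain would extend the gap between the two cores or close it. Going by these compounds, it is equally open whether an amine such as dimethylamino, in place of methyl(propargyl)amino, would show the same dependence on the core.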